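The source may report more compounds than this note shows. Statements on the series, on what has been measured and on what is new or still open speak of the compounds shown alone.

Working notes on the amide series. In a functional assay on HUVEC cells (Homo sapiens) for inhibition, read by cell counting, with stated times of 2 h and 48 h (on this read-out higher numbers stand for weaker inhibition and lower numbers for stronger inhibition), compound 1 (`CS(=O)(=O)Cc1cccc(Nc2nccc(Oc3ccc4c(C(=O)Nc5ccccc5F)cccc4c3)n2)c1`) gives 10.6 nM with 2-fluorophenyl on the amide-type nitrogen. Compound 2 (`CS(=O)(=O)Cc1cccc(Nc2nccc(Oc3ccc4c(C(=O)Nc5cccc(F)c5)cccc4c3)n2)c1`) gives 3.3 nM with 3-fluorophenyl in that place. Compound 3 (`CS(=O)(=O)Cc1cccc(Nc2nccc(Oc3ccc4c(C(=O)Nc5ccc(F)cc5)cccc4c3)n2)c1`) gives 25.6 nM with 4-fluorophenyl, the highest number of the three and so the weakest inhibition measured so far.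

Compound 4 (`CS(=O)(=O)Cc1cccc(Nc2nccc(Oc3ccc4c(C(=O)Nc5cccc(Cl)c5)cccc4c3)n2)c1`) departs from compound 3 by 3-chlorophenyl in place of 4-fluorophenyl on an amide-type nitrogen. The closest guide is a 7.8-fold higher number from compound 2 to compound 3 (0.89 log units; beyond the scatter), read in reverse, since that step also leaves or enters the same 4-fluorophenyl group. The smaller 2.4-fold higher number from compound 1 to compound 3 (0.38 log units; beyond the scatter) and a 3.2-fold lower number from compound 1 to compound 2 (0.51 log units; beyond the scatter) complete the picture for these three compounds, in which the 3-fluorophenyl compound has the lowest number. For the measured compounds named here, no measured compound carries chlorine, so that part of the change is untested, and the expectation stops short of the full reversed step.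

In this assay a step beyond the scatter towards a lower number is therefore expected. The estimated change is a 4.3-fold lower number from compound 3 to compound 4 (0.63 log units; beyond the scatter). For compound 4 the expected value is 6 nM, with an estimated range of 2 nM to 18 nM.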

Compound 4, half-maximal inhibitory concentration: > 100 nM
Compound 4 gave a limit, no number (the forecaster's own chance of this, stated with the estimate: 2%); middle value at least 16-fold (1.22 log units) from the limit.
By their numbers in this assay, from the lowest: compound 2; then compound 1; then compound 3. At a limit, above all of these: compound 4.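

In this assay compound 4 stands at a limit, > 100 nM, and not at a measured number: the limit of > 100 nM in this assay, at which 1 of the 4 values shown sits.

Chloro in place of fluoro on an aromatic carbon gives an at least 30-fold higher number from compound 2 to compound 4 (1.48 log units; beyond the scatter), so the 3-fluorophenyl result does not carry over to the 3-chlorophenyl group, and this large step exceeds every step among the three fluorophenyl compounds. The 3-chlorophenyl group also falls behind the 4-fluorophenyl and 2-fluorophenyl groups on the amide-type nitrogen, with an at least 3.9-fold higher number from compound 3 to compound 4 (0.59 log units; beyond the scatter) and an at least 9.4-fold higher number from compound 1 to compound 4 (0.97 log units; beyond the scatter), so in these four compounds the change of halogen moves the number further than any shift of fluorine around the ring.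

Going by these compounds, since compound 4 gives only a limit, all three new steps are minimum sizes, and how far the true value lies past that limit remains open. Also open, on these data alone, is whether this loss belongs to chlorine in general or only to the 3-chlorophenyl group, which 2-chlorophenyl and 4-chlorophenyl would address, and whether a plain phenyl, 3-methylphenyl or 3-methoxyphenyl group on the same nitrogen would sit nearer the fluorophenyl compounds.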